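This account rests on a few compounds, and the source may have more. Where it says the series, first, only, none or still open, it means among the compounds named here.

Measured so far, in an assay on isolated protein for inhibition of ribosyldihydronicotinamide dehydrogenase [quinone] (Homo sapiens), read by spectrophotometry, with a stated time of 1 min; on this read-out higher numbers stand for weaker inhibition and lower numbers for stronger inhibition:

compound 1, `Cn1c(-c2ccccc2)ccc1-c1ccc(C(=N)N)cc1`, 943 nM
compound 2, `N=C(N)c1ccc(-c2ccc(-c3ccc([N+](=O)[O-])cc3)o2)cc1`, 24 nM
compound 3, `N=C(N)c1ccc(-c2ccc(-c3cccc([N+](=O)[O-])c3)o2)cc1`, 28 nM

Compound 3 stands second highest of the three numbers in this assay. Its nearest neighbour is compound 2, whose number lies within the scatter of that of compound 3, so the two cannot be told apart; compound 1, which carries a different core and an unsubstituted phenyl ring, gives a number far higher than compound 3, beyond the scatter.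

Compound 4, `N=C(N)c1ccc(-c2ccc(-c3cccc(F)c3)o2)cc1`, has not yet been measured in this assay. It differs from compound 3 in one place: fluoro in place of nitro on an aromatic carbon. Among the measured compounds shown here, no measured pair shows this change, so its size is not known from the data. The nearest information is that compounds 2 and 3, which both carry a nitro group, lie close together, and compound 1, which carries no such group, lies far weaker; that pair is not a single-step comparison. A moderate step toward weaker inhibition is therefore expected from compound 3 to compound 4, of about a 2.9-fold higher number from compound 3 to compound 4 (0.46 log units; beyond the scatter). Compound 4 is estimated at 80 nM in this assay, with a range from 20 nM to 320 nM.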

Compound 4, half-maximal inhibitory concentration: 111 nM
Compound 4: middle estimate off by 1.4-fold (0.14 log units), on the low side, within the range that was stated.
By their numbers in this assay, from the lowest: compounds 2 and 3 (each within the scatter of the next); then compound 4; then compound 1.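

In this assay, among the compounds shown here, the change of nitro to fluoro on an aromatic carbon, meta to a large group, gives a 4.0-fold higher number from compound 3 to compound 4 (0.60 log units; beyond the scatter) and is the first single-place comparison at this position. It shows that inhibition at this position responds to the substituent, and that compound 4 still gives a measurable number of 111 nM without the nitro group. Nothing measured here explains why the number rises with this change.

As far as these compounds go, a single step cannot show whether the number follows the loss of nitro or the arrival of fluoro, and it remains open how a chlorine, a methoxy group, an amine or a carboxylic acid would read at the same place. From the compounds shown here alone, it also remains open whether the same swap on compound 2 would give a step of similar size.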